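Swapping a trimethoxyphenyl for cyclohexyl on a pyrazolopyridine amine

The compounds below may be only part of what the source reports. "The series", "measured", "known", "first", "only" and "open" are said of these compounds alone.

Measured compounds:
- compound 1 `COc1ccc(Cn2nc(-c3ccccc3)c3cc(C(=N)Nc4ccc(N5CCN(C)CC5)cc4)nc(Nc4cc(OC)c(OC)c(OC)c4)c32)cc1`: 1240 nM
- compound 2 `COc1cc(Nc2nc(C(=N)Nc3cccc(C(F)(F)F)c3)cc3c(-c4ccccc4)n[nH]c23)cc(OC)c1OC`: 13900 nM
- compound 3 `COc1ccc(Cn2nc(-c3ccccc3)c3cc(C(=N)Nc4ccc(N5CCN(C)CC5)cc4)nc(NC4CCCCC4)c32)cc1`: 3540 nM

In a functional assay on PC-3 cells (Homo sapiens) for cytotoxicity, read by MTT assay, with a stated time of 72 h (a lower number here means a stronger inhibitor, a higher number a weaker inhibitor), compound 1 gives 1240 nM. Compound 3 `COc1ccc(Cn2nc(-c3ccccc3)c3cc(C(=N)Nc4ccc(N5CCN(C)CC5)cc4)nc(NC4CCCCC4)c32)cc1` differs from it in one place: cyclohexyl in place of 3,4,5-trimethoxyphenyl on a nitrogen on an aromatic ring. That change produced a 2.9-fold higher number from compound 1 to compound 3 (0.46 log units; beyond the scatter), so the cyclohexyl compound is the weaker of the two.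

Compound 2 carries a different core from compound 1; how the two cores differ is not broken down here. In this assay compound 2 gives 13900 nM, the highest of the three measured numbers, and its number is well beyond the scatter from both compound 1 and compound 3.

Compound 4 `N=C(Nc1cccc(C(F)(F)F)c1)c1cc2c(-c3ccccc3)n[nH]c2c(NC2CCCCC2)n1` is not yet measured. It stands to compound 2 exactly as compound 3 stands to compound 1: cyclohexyl in place of 3,4,5-trimethoxyphenyl on a nitrogen on an aromatic ring. The place of the change is described in the same words for both pairs, so this is the same change, made on a second core.

Going by the values given here, only one earlier instance of this change is available, and it weakened the compound. Resting on a 2.9-fold higher number from compound 1 to compound 3 (0.46 log units; beyond the scatter), compound 4 is expected to be weaker than compound 2 by roughly a similar step, estimated as a 2.7-fold higher number from compound 2 to compound 4 (0.44 log units; beyond the scatter). Compound 4 is therefore estimated at 38000 nM, most likely between 12000 nM and 120000 nM. Because compound 2 already sits at 13900 nM, a further weakening may push compound 4 toward the top of what this assay can report.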

Compound 4, half-maximal inhibitory concentration: 25000 nM
Compound 4: the middle estimate sits 1.5-fold (0.18 log units) above what was measured; measured number inside the range.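

In this assay, putting cyclohexyl in place of 3,4,5-trimethoxyphenyl on the second core gives a 1.8-fold higher number from compound 2 to compound 4 (0.25 log units; within the scatter), a step too small to separate the two compounds. Set beside the first instance of this change, the second gives no sign that the core alters its effect: the same change on two cores in this assay, a 2.9-fold higher number (0.46 log units; beyond the scatter) from compound 1 to compound 3 and a 1.8-fold higher number (0.25 log units; within the scatter) from compound 2 to compound 4, 1.6-fold (0.20 log units) apart, within the scatter of two such steps This shows only that the two readings agree within the noise of the assay, not that the step is the same size on both cores, and the step on the second core cannot by itself be taken as a real loss of activity; two pairs also make no rule for any further core in this series.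

The compounds shown leave open how other groups on this nitrogen would behave on either core, for example a simple amine with no ring on it, a short ethyl chain or a benzyl group. Going by these compounds alone, they also leave open what each separate difference between the two cores contributes, since compounds 1 and 2 differ in more than one place and no compound here isolates any one of those differences.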